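The compounds below may be only part of what the source reports. "The series", "measured", "known", "first", "only" and "open" are said of these compounds alone.

Measured compounds:

Compound 1 `O=C(OC1CCC(CN2CCN(c3cc(=O)c4cc(C(F)(F)F)cc([N+](=O)[O-])c4s3)CC2)CC1)C1CCCCC1`. In an ADME assay on Vero cells (Chlorocebus sabaeus) for cytotoxicity, read by MTT assay, with a stated time of 48 h (a lower number here means a stronger inhibitor, a higher number a weaker inhibitor), compound 1 gives > 64 ug/mL, which is a limit of the assay and not a number.
Compound 2 `O=C(OC1CCC(CN2CCN(c3cc(=O)c4cc(C(F)(F)F)cc([N+](=O)[O-])c4s3)CC2)CC1)c1ccco1`. In this assay compound 2 gives > 64 ug/mL, again a limit.
Compound 3 `Cc1ccc(C(=O)OC2CCC(CN3CCN(c4cc(=O)c5cc(C(F)(F)F)cc([N+](=O)[O-])c5s4)CC3)CC2)cc1`. In this assay compound 3 gives > 64 ug/mL, also a limit.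

Compound 3 therefore stands only at a limit, and every value in the set sits at the same place, as shown by the limit of > 64 ug/mL in this assay, at which 3 of the 3 values shown sit. The three compounds differ only in the acyl group of the ester: a step that the two limits leave unreadable from compound 1 to compound 2, a step that the two limits leave unreadable from compound 1 to compound 3 and a step that the two limits leave unreadable from compound 2 to compound 3. None of these steps can be read, since the values on both sides are limits.

Compound 4 `O=c1cc(N2CCN(CC3CCC(NS(=O)(=O)c4ccccc4)CC3)CC2)sc2c([N+](=O)[O-])cc(C(F)(F)F)cc12` is the next member. It differs from compound 3 as follows: (phenylsulfonyl)amino in place of ((4-methylphenyl)carbonyl)oxy on a saturated ring carbon. This change sits on the same saturated ring carbon that the three measured steps altered, but it exchanges the whole ester linkage for a sulfonamide rather than swapping one acyl group for another, so the measured steps give only a weak hint. That hint is that nothing done at this position has yet brought a value below the limit.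

On that basis compound 4 is expected to behave like compound 3, with a step that the limit leaves unreadable from compound 3 to compound 4 in this assay, most likely none beyond the scatter. The estimate for compound 4 is 80 ug/mL, in the range 35 ug/mL to 200 ug/mL, with a real chance that only a limit is reported.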

Compound 4, half-maximal inhibitory concentration: > 64 ug/mL
Compound 4 ended at the assay's limit (the forecaster's own chance of this, stated with the estimate: 70%); the middle value is on the limit's open side.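

Compound 4 gives > 64 ug/mL in this assay, a limit and not a number. Its steps from compound 1, compound 2 and compound 3 therefore cannot be read. The compounds shown leave open whether any of these groups on the saturated ring carbon changes the read-out, since the whole series stands at one place: the limit of > 64 ug/mL in this assay, at which 4 of the 4 values shown sit.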